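From acetyl to phenylsulfonyl on the shared core

A few compounds are considered here, and "the series" means these few. Any claim that something is new, unique, unknown or untested is made for them only; others in the source may bear on it.

In a functional assay on HCT-116 cells (Homo sapiens) for cytotoxicity, read by sulforhodamine B assay, with a stated time of 24 h (a higher number here means a weaker inhibitor, a lower number a stronger inhibitor), compound 1 (`N=c1oc2ccccc2cc1C(=O)N/N=C1\C(=O)Nc2ccc(S(=O)(=O)N3CCOCC3)cc21`) gives 6750 nM and compound 2 (`CC(=O)N/N=C1\C(=O)Nc2ccc(S(=O)(=O)N3CCOCC3)cc21`) gives 29000 nM on the same read-out. Compound 2 therefore holds the higher of the two numbers and is the weaker inhibitor of the pair, with the gap beyond the scatter.

Compound 3 (`O=C1Nc2ccc(S(=O)(=O)N3CCOCC3)cc2/C1=N/NS(=O)(=O)c1ccccc1`) keeps the shared core and carries phenylsulfonyl in place of acetyl on an amine nitrogen.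

Among the compounds with values here, only one measured step bears on this change: a 4.3-fold higher number from compound 1 to compound 2 (0.63 log units; beyond the scatter) when a ring-bearing group on a carbonyl carbon gives way to one carbon atom. Within the data shown here, that step is modest and sits at a different kind of group, since no measured compound has a sulfonyl group on this nitrogen. Compound 3 does regain an aromatic ring, so a move in the reverse direction, toward a lower number, is expected, but probably a smaller one. The estimated move is a 2.2-fold lower number from compound 2 to compound 3 (0.35 log units; beyond the scatter) and remains uncertain, resting on a single pair. For compound 3 the estimate is 13000 nM (expected range 4500 nM to 35000 nM).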

Compound 3, half-maximal inhibitory concentration: 13300 nM
For compound 3 the middle estimate is 1.0-fold (0.01 log units) below the measured one; low and high end bracket the measured number.
By their numbers in this assay, from the lowest: compounds 1 and 3 (each within the scatter of the next); then compound 2.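

Within the data shown here, on the amine nitrogen whose other neighbour is the double-bonded nitrogen, a sulfonyl link now appears for the first time, and in this assay the exchange of acetyl for phenylsulfonyl gives a 2.2-fold lower number from compound 2 to compound 3 (0.34 log units; beyond the scatter) as a modest step. The position therefore accepts more than carbonyl-linked groups without the number rising, and the ring-bearing groups of compound 1 and compound 3 both give lower numbers than compound 2 while lying within the scatter of each other. Among these compounds, none of the three compounds goes against the reading that a ring-bearing group here gives a lower number than acetyl, though that reading rests on only two such groups.

No measurement at hand accounts for the step.

From the compounds shown here alone, the exchange alters the ring and the linking group together, so the share of each stays open; benzoyl and methylsulfonyl on this nitrogen would separate them. Also open, going by these compounds, is how the number responds to a methoxy group, a chlorine atom or an amine carried on the phenyl ring.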